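Replacing the chain-end nitrile with a methylsulfonyl group

The compounds below may be only part of what the source reports. "The series", "measured", "known", "first", "only" and "open" are said of these compounds alone.

Working notes on the series. Compound 1 `CCc1cc(C(C)=O)c(O)cc1OCCCCC(C)(C)C#N` gives 79% in an assay on isolated protein for inhibition of leukotriene B4 receptor 1 (Homo sapiens), tested at 10 uM (on this read-out higher numbers stand for more inhibition at the one concentration tested (going by the name of the read-out) and lower numbers for less inhibition), and stands as the lower of the two numbers in hand. Compound 2 `C=CCc1cc(C(C)=O)c(O)cc1OCCCCCC(C)(C)O` gives 98% in this assay, a gap beyond the scatter. Compound 3 `CCc1cc(C(C)=O)c(O)cc1OCCCCCCS(C)(=O)=O` is not yet measured; against compound 1 the change is 2-(methylsulfonyl)ethyl in place of 1-cyano-1-methylethyl on a saturated chain carbon, four bonds along the chain from an oxygen on an aromatic ring. Among the compounds with values here, no measured pair covers this change, so no step can be read off. The expected step of a number 1 percentage points higher from compound 1 to compound 3 (within the scatter) in this assay is estimated to stay within the scatter, with no clear direction. Compound 3 is therefore expected near 80%, between 55% and 97%.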

Compound 3, a percentage reported as inhibition, at one concentration (the size of the read-out at that concentration, not a potency): 99%
Compound 3: the middle estimate sits 19 percentage points below what was measured, and the stated range ends below it.
By their numbers in this assay, from the lowest: compound 1; then compounds 2 and 3 (each within the scatter of the next).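

In this assay, 2-(methylsulfonyl)ethyl in place of 1-cyano-1-methylethyl on this saturated chain carbon gives a number 20 percentage points higher from compound 1 to compound 3 (beyond the scatter). The position therefore accepts a chain end without the nitrile and with no loss of inhibition at the one concentration tested. Nothing on hand explains the step.

On these data alone, whether a carboxylic acid or an amine at the chain end would keep this level of inhibition remains open. A single concentration also leaves open how far the potencies of compound 1 and compound 3 differ.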